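Benzoxazole to methylamide: expected cytotoxicity of compound 4

The source may hold more compounds than are shown below. What is called first, only, known or untested is meant among the compounds shown, and "the series" means these compounds.

Compound 1 `COC(=O)c1ccc(NCc2cncn2Cc2ccccc2C#N)cc1-c1ccccc1` in a toxicity assay on NIH3T3 cells (Mus musculus) for cytotoxicity, read by resazurin assay (a lower number here means that less compound is needed, a higher number that more compound is needed for the effect), gives 25000 nM.
Compound 2 `c1ccc(-c2ccc(Cn3cncc3CNc3ccc(-c4ccccc4)c(-c4ccccc4)c3)cc2)cc1` gives > 10000 nM, a limit of the assay rather than a number.
Compound 3 `c1ccc(-c2ccc(Cn3cncc3CNc3ccc(-c4nc5ccccc5o4)c(-c4ccccc4)c3)cc2)cc1` gives > 10000 nM, likewise a limit.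

Compound 3 therefore sits at the limit of > 10000 nM in this assay, at which 2 of the 3 values shown sit. Within the data shown here, the only measured step, a step that the two limits leave unreadable from compound 2 to compound 3, gives no readable size, since both ends are limits. Compound 4 `CNC(=O)c1ccc(NCc2cncn2Cc2ccc(-c3ccccc3)cc2)cc1-c1ccccc1` differs from compound 3 by methylcarbamoyl in place of 1,3-benzoxazol-2-yl on an aromatic carbon. Among the measured compounds shown here, no measured step bears on this change, so no direction beyond the scatter is expected in this assay. Compound 1 alone gives a number rather than a limit. For compound 4 the estimated value in this assay is 20000 nM, expected to lie between 5000 nM and 60000 nM. The expected step is thus a step that the limit leaves unreadable from compound 3 to compound 4.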

Compound 4, half-maximal effective concentration: > 1000 nM
Compound 4 ended at the assay's limit (the forecaster's own chance of this, stated with the estimate: 50%); the middle value is on the limit's open side.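

In this assay compound 4 gives > 1000 nM as a limit of the assay. Among these compounds, compound 2 and compound 3 also stand at limits, so no step to compound 4 can be read. From the compounds shown here alone, whether methylcarbamoyl in place of 1,3-benzoxazol-2-yl or phenyl changes the cytotoxicity at all remains open.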